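This account rests on a few compounds, and the source may have more. Where it says the series, first, only, none or still open, it means among the compounds named here.

Measured so far:
compound 1 `NC1=NC2(CCSCC2)N(OCCCOc2cccc(Cl)c2)C(N)=N1` — 90 nM
compound 2 `NC1=NC2(CCOCC2)N(OCCCOc2ccc(Cl)cc2)C(N)=N1` — "not determined" (no result reported)
compound 3 `NC1=NC2(CCOCC2)N(OCCCOc2ccccc2Br)C(N)=N1` — 860 nM

In a functional assay on HepG2 cells (Homo sapiens) for antiproliferative activity, read by MTT assay, with a stated time of 72 h (on this read-out lower numbers stand for stronger inhibition and higher numbers for weaker inhibition), compound 1 gives 90 nM, the lower of the two numbers available; compound 3 gives 860 nM, a gap that lies beyond the usual scatter. For compound 2 no result was reported. Compound 4 `NC1=NC2(CCSCC2)N(OCCCOc2ccccc2Br)C(N)=N1` is not yet measured. It differs from compound 1 in one place: 2-bromophenyl in place of 3-chlorophenyl on an oxygen on a saturated carbon. Among the compounds with values here, no pair of measured compounds isolates this change, so its size is unknown. Compound 3 also bears the 2-bromophenoxy group and gives 860 nM, which points toward a weaker result for compound 4. The step of a 4.4-fold higher number from compound 1 to compound 4 (0.65 log units; beyond the scatter) is expected to be a loss beyond the scatter. Compound 4 is expected near 400 nM, with a range from 120 nM to 1500 nM.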

Compound 4, half-maximal inhibitory concentration: 90 nM
The estimate for compound 4 lay 4.4-fold (0.65 log units) above the measured number; measured number below the stated range.
By their numbers in this assay, from the lowest: compounds 1 and 4 (each within the scatter of the next); then compound 3.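

In this assay 2-bromophenyl in place of 3-chlorophenyl on the oxygen gives no change at the digits printed from compound 1 to compound 4 (within the scatter) and so shows that this position takes either halogenated phenyl. Compound 4 gives 90 nM and compound 3 gives 860 nM with the same 2-bromophenoxy group, so that group alone does not set the higher number. No measurement at hand explains this result.

Open, from the compounds shown here alone, is whether an amine or a carboxylic acid on the phenyl ring would keep this level. Compound 2 offers no number for comparison.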